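Iodo to phenyl on the shared core: compound 4 outlook

A few compounds are considered here, and "the series" means these few. Any claim that something is new, unique, unknown or untested is made for them only; others in the source may bear on it.

Measured so far:
Compound 1, `Nc1nc(N)c2c(-c3ccsc3)cn([C@@H]3O[C@H](CO)[C@@H](O)[C@H]3O)c2n1`, in a functional assay on CEM-DNR-bulk cells (Homo sapiens), read by MTT assay, with a stated time of 72 h (a lower number here means a stronger inhibitor, a higher number a weaker inhibitor), gives > 20000 nM, a limit of the assay.
Compound 2, `COc1ncnc2c1c(I)cn2[C@@H]1O[C@H](CO)[C@@H](O)[C@H]1O`, in this assay gives > 20000 nM, a limit of the assay.
Compound 3, `Nc1nc(N)c2c(-c3ccoc3)cn([C@@H]3O[C@H](CO)[C@@H](O)[C@H]3O)c2n1`, in this assay gives > 20000 nM, a limit of the assay.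

Compound 2 therefore stands at the limit, together with every other value shown: the limit of > 20000 nM in this assay, at which 3 of the 3 values shown sit. For the measured compounds named here, nothing among the measured compounds separates it from the others in this assay.

Going by the values given here, the only measured step, a step that the two limits leave unreadable from compound 1 to compound 3, concerns a change on a different part of the core and is unreadable, both ends being limits; it says nothing about the change considered here.

Compound 4 is `COc1ncnc2c1c(-c1ccccc1)cn2[C@@H]1O[C@H](CO)[C@@H](O)[C@H]1O`, not yet measured. It differs from compound 2 as follows: phenyl in place of iodo on an aromatic carbon. Among the compounds with values here, no measured step bears on this change, so no direction can be read from the data; the expectation rests only on the fact that all three values sit at the limit.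

Compound 4 is expected in this assay at about 20000 nM, within 4000 nM to 100000 nM, most probably again reported as a limit. The step that this estimate means, a number no higher from compound 2 to compound 4 (the limit leaves the size open), is expected to be none beyond the scatter.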

Compound 4, half-maximal inhibitory concentration: > 20000 nM
Compound 4: a limit, no number (the forecaster's own chance of this, stated with the estimate: 70%); the middle value sits exactly at the limit.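

Compound 2 and compound 4 both stand as limits in this assay, so no step can be read for phenyl in place of iodo: the limit of > 20000 nM in this assay, at which 4 of the 4 values shown sit.

The compounds shown leave open whether any change on the shared core brings a value inside the limit.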